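Swapping chloro for fluoro beside the methylsulfonyl group

This account rests on a few compounds, and the source may have more. Where it says the series, first, only, none or still open, it means among the compounds named here.

Compound 2 `CS(=O)(=O)c1ccc(Cl)c(C#Cc2cc(Cl)ccc2OCC(=O)O)c1` has the lowest number of the two measured compounds in a functional assay on cells for antagonist activity at prostaglandin D2 receptor 2 (Homo sapiens), read by flow cytometry, with a stated time of 10 min (on this read-out lower numbers stand for stronger inhibition and higher numbers for weaker inhibition), giving 26 nM, while compound 1 `CC(C)c1ccc(S(C)(=O)=O)cc1C#Cc1cc(Cl)ccc1OCC(=O)O` gives 360 nM. For the measured compounds named here, the only measured step, a 14-fold lower number from compound 1 to compound 2 (1.14 log units; beyond the scatter), came from chloro in place of isopropyl, a different change at this same position. Compound 3 `CS(=O)(=O)c1ccc(F)c(C#Cc2cc(Cl)ccc2OCC(=O)O)c1` differs from compound 2 by fluoro in place of chloro on an aromatic carbon. Going by the values given here, no measured step shows what trading chloro for fluoro does here; the expectation rests on each change involving a single heavy atom. Compound 3 is expected to show a modest rise in number, a 2.3-fold higher number from compound 2 to compound 3 (0.36 log units; beyond the scatter), giving an estimated 60 nM within a range of 20 nM to 180 nM.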

Compound 3, half-maximal inhibitory concentration: 95 nM
For compound 3 the middle estimate is 1.6-fold (0.20 log units) below the measured one, within the range that was stated.
By their numbers in this assay, from the lowest: compound 2; then compound 3; then compound 1.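

Here, para to a methylsulfonyl group, the two halogens are not interchangeable, even though each is a single heavy atom: the swap gives a 3.7-fold higher number from compound 2 to compound 3 (0.56 log units; beyond the scatter). Fluoro still does better than isopropyl, with a 3.8-fold lower number from compound 1 to compound 3 (0.58 log units; beyond the scatter), so the three groups rank chloro, fluoro, isopropyl from lowest number to highest. Nothing available explains this order. Still open, going by these compounds, is where a bromo, a methyl or an amine would fall in this ranking, and whether the same order would hold with changes elsewhere on the shared core.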